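This account rests on a few compounds, and the source may have more. Where it says the series, first, only, none or still open, it means among the compounds named here.

Series notes. In an assay on HEK293 cells for inhibition of transient receptor potential cation channel subfamily M member 8 (Homo sapiens), read by FLIPR, with stated times of 5 min and 3 min (on this read-out lower numbers stand for stronger inhibition and higher numbers for weaker inhibition), compound 1 `O=C(c1sc(-c2ccccc2O)nc1O)N1CCCCO1` gives 81 nM. Compound 2 `O=C(c1sc(-c2cccc(F)c2)nc1O)N1CCCCO1`, which carries 3-fluorophenyl in place of 2-hydroxyphenyl on an aromatic carbon, gives 167 nM in this assay; the step is a 2.1-fold higher number from compound 1 to compound 2 (0.31 log units; beyond the scatter). Going by the values given here, compound 2 therefore stands highest of the two numbers measured so far, with compound 1 as its nearest neighbour.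

Compound 3 `O=C(c1sc(-c2cccc(F)c2)nc1O)N1CCCCCO1` differs from compound 2 by a group of 7 heavy atoms (5 carbon, 1 nitrogen, 1 oxygen; one seven-membered non-aromatic ring with 2 hetero atoms) in place of a group of 6 heavy atoms (4 carbon, 1 nitrogen, 1 oxygen; one six-membered non-aromatic ring with 2 hetero atoms), on a carbonyl carbon. Among the compounds with values here, the only measured step, a 2.1-fold higher number from compound 1 to compound 2 (0.31 log units; beyond the scatter), concerns a change on an aromatic carbon and does not bear on a change at the carbonyl carbon; no measured pair speaks to this kind of alteration. With nothing to lean on, the step is expected to be a 1.0-fold higher number from compound 2 to compound 3 (0.01 log units; within the scatter), nothing beyond the scatter in either direction. The estimate for compound 3 in this assay is accordingly 170 nM, within 60 nM to 500 nM.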

Compound 3, half-maximal inhibitory concentration: 32 nM
For compound 3 the middle estimate is 5.3-fold (0.73 log units) above the measured one, and the stated range ends above it.
By their numbers in this assay, from the lowest: compound 3; then compound 1; then compound 2.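

In this assay, the group on the carbonyl carbon proves to be a sensitive point: the seven-membered non-aromatic ring with 2 hetero atoms, in place of the six-membered one, gives a 5.2-fold lower number from compound 2 to compound 3 (0.72 log units; beyond the scatter), which means stronger inhibition. Going by these compounds alone, the earlier pair varied only the aromatic substituent, so this is the first sign that ring size at the carbonyl carbon can move the read-out beyond the scatter, here with the 3-fluorophenyl group held constant. Nothing available accounts for this gain.

Going by these compounds, whether the seven-membered ring gives a similar step alongside the 2-hydroxyphenyl group of compound 1 remains open. Also open, on these data alone, is how an eight-membered ring, or a piperidine or azepane amide lacking the ring oxygen, would read in this assay.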